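A few compounds are considered here, and "the series" means these few. Any claim that something is new, unique, unknown or untested is made for them only; others in the source may bear on it.

Of the compounds shown here, two have been measured in a functional assay on MIA PaCa-2 cells (Homo sapiens) for inhibition, read by MTT assay, with a stated time of 48 h, tested at 10 uM; a lower number here means less inhibition of growth, a higher number more inhibition of growth at the concentration tested. Compound 1, with the structure `Cc1cc(=O)c2c(O)c(CN(C(C)C)C(C)C)c(O)c([C@H]3CCN(C)C[C@H]3O)c2o1`, gives 11%. Compound 2, with the structure `Cc1oc2c([C@H]3CCN(C)C[C@H]3O)c(O)cc(O)c2c(=O)c1C(O)c1ccc(Cl)cc1`, gives 15%. For the measured compounds named here, of the two numbers, the one for compound 2 is the higher, but its gap to compound 1 is within the usual scatter of this measurement, so the two compounds cannot be told apart on these values alone; both sit at the low end of what this assay can report.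

Compound 3, with the structure `Cc1oc2c([C@H]3CCN(C)C[C@H]3O)c(O)cc(O)c2c(=O)c1C(O)c1cccc(Cl)c1Cl`, has not yet been measured. It differs from compound 2 in one place: 2,3-dichlorophenyl in place of 4-chlorophenyl on a saturated chain carbon bound to an aromatic carbon and an oxygen on a saturated carbon. The shared core, the ring bearing the hydroxy groups and the saturated ring attached to it, is kept unchanged.

Going by the values given here, no measured pair here shows what such a change does in this assay, so there is nothing to lean on except the low values of compound 1 and compound 2. The step from compound 2 to compound 3 is therefore expected to be small, a number 3 percentage points higher from compound 2 to compound 3 (within the scatter), most likely staying within the scatter. Compound 3 is expected to give about 18%, with a plausible range from 5% to 35%.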

Compound 3, percent growth inhibition at one concentration: 2%
Estimate against measurement, compound 3: 16 percentage points above, outside the stated range (below it).
By their numbers in this assay, from the lowest: compounds 3, 1 and 2 (each within the scatter of the next, the first and the last beyond it).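

For the compounds shown here, replacing 4-chlorophenyl with 2,3-dichlorophenyl on the saturated chain carbon gives the first step that can be read in this assay: a number 13 percentage points lower from compound 2 to compound 3 (beyond the scatter). This shows that the aryl group at this position can change the reading even while the shared core stays the same, and that this particular change lowers growth inhibition at the concentration tested rather than raising it. The step is modest, however, and it starts from a compound that already inhibits growth only weakly, so it shows a loss from a low level and not the removal of a strong effect; nothing available here accounts for the drop.

These compounds cannot separate the effect of having a second chlorine from the effect of where the chlorines sit, since 2,3-dichlorophenyl differs from 4-chlorophenyl in both respects. They also leave open how an unsubstituted phenyl, a fluorophenyl or a methoxyphenyl group would behave at this position, and whether an amine in place of the hydroxy group on the same carbon would lift the low values seen so far.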